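Removing a Protecting Group from a Biphenyl Polyamine

This account rests on a few compounds, and the source may have more. Where it says the series, first, only, none or still open, it means among the compounds named here.

Of the compounds shown here, three have been tested in an ADME assay on RAW264.7 cells (Mus musculus) for cytotoxicity, read by resazurin assay, with a stated time of 48 h; a higher number here means that more compound is tolerated, a lower number that less compound is tolerated. Compound 1 `CC(C)(C)OC(=O)NCCCCNCCCN(Cc1ccc(OCc2ccccc2)cc1)Cc1ccc(OCc2ccccc2)cc1` gives 33300 nM. Compound 3 `NCCCCNCCCN(Cc1ccccc1)Cc1ccccc1` gives 17700 nM. Compound 2 `CC(C)(C)OC(=O)NCCCCNCCCN(Cc1ccc(-c2ccccc2)cc1)Cc1ccc(-c2ccccc2)cc1` gives only a limit of the assay, > 100000 nM, and not a number. Compound 2 thus stands at the limit of > 100000 nM in this assay, at which 1 of the 3 values shown sits. Compound 1 and compound 3 both give plain numbers in this assay.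

Compound 4 `NCCCCNCCCN(Cc1ccc(-c2ccccc2)cc1)Cc1ccc(-c2ccccc2)cc1` has not yet been measured. It differs from compound 2 in one place: hydrogen in place of tert-butoxycarbonyl on an amine nitrogen, so that a free amine stands where compound 2 carries the carbamate. No pair of measured compounds differs only in this way, so the size of this step cannot be read from the numbers shown; compound 3, with its free amine, and compound 1, with its carbamate, also differ in their aromatic groups, so their values cannot be set against each other as a single step. A modest move toward a lower tolerated concentration is expected, close to the usual scatter. The expected step is an at least 2.2-fold lower number from compound 2 to compound 4 (0.34 log units; beyond the scatter). Compound 4 is expected to give about 45000 nM in this assay, between 15000 nM and 120000 nM, with a fair chance that it again reaches only a limit.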

Compound 4, half-maximal cytotoxic concentration: 4200 nM
The estimate for compound 4 lay 11-fold (1.03 log units) above the measured number; measured number outside the range, below it.
By their numbers in this assay, from the lowest: compound 4; then compounds 3 and 1 (each within the scatter of the next). At a limit, above all of these: compound 2.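

In this assay, replacing tert-butoxycarbonyl with hydrogen on the amine nitrogen gives an at least 23-fold lower number from compound 2 to compound 4 (1.37 log units; beyond the scatter). Among these compounds, this is the first single change that can be read, and it shows that the group on this nitrogen strongly affects how much compound the cells tolerate, at least on this core. Compound 2 gives only a limit of the assay, so the step is a minimum and its full size remains unknown: the limit of > 100000 nM in this assay, at which 1 of the 4 values shown sits.

From the compounds shown here alone, whether the same change has a similar effect on the core of compound 1 remains open, since compound 3 differs from compound 1 in its aromatic groups as well. It is also unclear whether a smaller acetyl group or a methyl group on this nitrogen would behave more like tert-butoxycarbonyl or more like hydrogen.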